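Trifluoromethyl for chloro: cytotoxicity on Vero cells

The source may hold more compounds than are shown below. What is called first, only, known or untested is meant among the compounds shown, and "the series" means these compounds.

Measured in an ADME assay on Vero cells (Chlorocebus sabaeus) for cytotoxicity, read by WST assay; a lower number here means that less compound is tolerated, a higher number that more compound is tolerated:
compound 1 `O=c1[nH]c(Nc2cc(Cl)cc(Cl)c2)nc2cc(Cl)ccc12` gives > 25000 nM
compound 2 `COc1cccc(Nc2nc3cc(Cl)ccc3c(=O)[nH]2)c1` gives > 25000 nM
compound 3 `O=c1[nH]c(Nc2cccc(O)c2)nc2cc(Cl)ccc12` gives > 25000 nM

Each of these three values is a limit of this assay and not a number. Compound 1 thus stands only at the limit, and on the numbers shown nothing separates it from compound 2 or compound 3. Going by the values given here, the one step measured between compounds that differ in a single place, a step that the two limits leave unreadable from compound 2 to compound 3, is left unreadable by the two limits on either side of it.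

Compound 4 `O=c1[nH]c(Nc2cc(Cl)cc(Cl)c2)nc2cc(C(F)(F)F)ccc12` differs from compound 1 by trifluoromethyl in place of chloro on an aromatic carbon. Among the compounds with values here, no measured step bears directly on this exchange; the only evidence is the limit of > 25000 nM in this assay, at which 3 of the 3 values shown sit, at which all three values rest. The step that the limit leaves unreadable from compound 1 to compound 4 is therefore expected to show nothing readable beyond the scatter. For compound 4 the estimate in this assay is 40000 nM, within 15000 nM to 200000 nM, and a further limit rather than a number is the most likely outcome.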

Compound 4, half-maximal cytotoxic concentration: 7100 nM
Beside the measured number, compound 4's estimate is 5.6-fold (0.75 log units) above it; measured number below the stated range.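

In this assay the exchange of chloro for trifluoromethyl gives an at least 3.5-fold lower number from compound 1 to compound 4 (0.54 log units; beyond the scatter), so a change at this aromatic carbon, meta and para to a fused ring, can bring the read-out off the limit. The rest of compound 1 stays unchanged in compound 4, which ties this step to that one place and shows that the shared core alone does not keep the series at the limit. Compound 4 now holds the only number in the set, and the other values remain limits: the limit of > 25000 nM in this assay, at which 3 of the 4 values shown sit.

On these data alone, it remains open whether a nitrile, an amine or a hydrogen at this carbon would also bring the read-out off the limit, or whether the step is particular to trifluoromethyl. As far as these compounds go, it is also open whether trifluoromethyl here would give a similar step with the substituents of compound 2 or compound 3 on the other ring.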